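Swapping Chloro for Fluoro on a Bithiophene Amidine

The source may report more compounds than this note shows. Statements on the series, on what has been measured and on what is new or still open speak of the compounds shown alone.

Measured compounds:
compound 1 `N=C(N)c1ccc(-c2ccc(-c3ccc(Cl)cc3)s2)s1`: 1830 nM
compound 2 `COc1cc(OC)cc(-c2ccc(-c3ccc(C(=N)N)o3)o2)c1`: 2300 nM

Of the compounds shown here, two have been tested in a functional assay on NCI-H522 cells (Homo sapiens) for inhibition, read by sulforhodamine B assay, with a stated time of 48 h; a lower number here means a stronger inhibitor of growth, a higher number a weaker inhibitor of growth. Compound 1 `N=C(N)c1ccc(-c2ccc(-c3ccc(Cl)cc3)s2)s1` carries an amidine on a core of two linked thiophenes and ends in a chlorophenyl group; in this assay compound 1 gives 1830 nM. Compound 2 `COc1cc(OC)cc(-c2ccc(-c3ccc(C(=N)N)o3)o2)c1` has a different core and a dimethoxyphenyl end, and in this assay compound 2 gives 2300 nM. The two numbers sit within the usual scatter of each other, so neither compound can be called the stronger inhibitor of growth on this evidence.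

The next compound, compound 3 `N=C(N)c1ccc(-c2ccc(-c3ccc(F)cc3)s2)s1`, keeps everything of compound 1 except the halogen on the phenyl ring: fluoro in place of chloro on an aromatic carbon. Going by the values given here, no measured pair shows what such a swap does here, so the expectation rests only on the small size of the change. A step from compound 1 to compound 3 of a 1.4-fold higher number from compound 1 to compound 3 (0.14 log units; within the scatter) is expected in this assay, most likely a modest shift toward a higher number and possibly none beyond the scatter. Compound 3 is therefore estimated at 2500 nM, with a plausible range from 1000 nM to 6500 nM.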

Compound 3, concentration for 50% growth inhibition: 1820 nM
Beside the measured number, compound 3's estimate is 1.4-fold (0.14 log units) above it; the range from low to high includes it.
By their numbers in this assay, from the lowest: compounds 3, 1 and 2 (each within the scatter of the next).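

In this assay the swap of chloro for fluoro, on an aromatic carbon of the six-membered ring and para to a large group, gives a 1.0-fold lower number from compound 1 to compound 3 (0.00 log units; within the scatter). Going by these compounds alone, this is the first pair that differs in one place only, and it gives a direct reading of this position: with the rest of compound 1 held fixed, either halogen can sit there with no change that stands out from the scatter. No measurement of any other property accompanies these two compounds, so nothing here explains why the number holds steady.

From the compounds shown here alone, the result covers only two halogens, so it remains open whether this position would tolerate a group of a different kind, such as an amine or a carboxylic acid, or a larger one, such as a longer chain. Going by these compounds, compound 2 differs from compound 1 and compound 3 in more than one place, so the separate contributions of its core and its dimethoxyphenyl end also remain open.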